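A few compounds are considered here, and "the series" means these few. Any claim that something is new, unique, unknown or untested is made for them only; others in the source may bear on it.

Of the compounds shown here, three have been measured in an assay on CHO cells for displacement of a labelled ligand from transient receptor potential cation channel subfamily V member 1 (Rattus norvegicus); a higher number here means a weaker inhibitor, a lower number a stronger inhibitor. Compound 1 `Cc1ccc(CC(CNC(=O)C(C)(C)c2ccc(NS(C)(=O)=O)cc2)COC(=O)C(C)(C)C)cc1C` gives 370 nM, compound 2 `COc1cc(C(C)(C)C(=O)NCC(COC(=O)C(C)(C)C)Cc2ccc(C)c(C)c2)ccc1NS(C)(=O)=O` gives 153 nM, and compound 3 `COc1cc(C2(C(=O)NCC(COC(=O)C(C)(C)C)Cc3ccc(C)c(C)c3)CC2)ccc1NS(C)(=O)=O` gives 239 nM. Compound 2 shows the lowest of the three numbers; its gap to compound 3 lies within the scatter, while its gap to compound 1 lies beyond it. Compound 4 `Cc1ccc(CC(CNC(=O)C(C)(C)c2ccc(NS(C)(=O)=O)c(F)c2)COC(=O)C(C)(C)C)cc1C` differs from compound 2 by fluoro in place of methoxy on an aromatic carbon. For the measured compounds named here, the only measured step that bears on this change is a 2.4-fold lower number from compound 1 to compound 2 (0.38 log units; beyond the scatter), where a methoxy entered at this carbon; no measured step shows a fluoro there, so the fluoro is treated as standing between hydrogen and methoxy. For compound 4 the expected step is a 1.6-fold higher number from compound 2 to compound 4 (0.21 log units; within the scatter), a modest rise in the number. The estimate for compound 4 is 250 nM, with a range from 110 nM to 600 nM.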

Compound 4, inhibition constant: 280 nM
Compound 4: the middle estimate sits 1.1-fold (0.05 log units) below what was measured, and the stated range covers the measured number.
By their numbers in this assay, from the lowest: compounds 2, 3, 4 and 1 (each within the scatter of the next, the first and the last beyond it).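

In this assay, this aromatic carbon, ortho to a methanesulfonamido group, now has a third group to compare. Fluoro in place of methoxy gives a 1.8-fold higher number from compound 2 to compound 4 (0.26 log units; within the scatter), and fluoro in place of hydrogen gives a 1.3-fold lower number from compound 1 to compound 4 (0.12 log units; within the scatter). Fluoro therefore cannot be told apart from either group, although methoxy and hydrogen themselves are separated by a 2.4-fold lower number from compound 1 to compound 2 (0.38 log units; beyond the scatter). No measurement shown gives a reason for these numbers. On these data alone, how a chloro, an ethoxy or an amine at this carbon would compare remains open.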